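The source may hold more compounds than are shown below. What is called first, only, known or untested is meant among the compounds shown, and "the series" means these compounds.

Three compounds have been measured in a functional assay on cells (Panel NCI-60 (60 carcinoma cell lines), Homo sapiens); a lower number here means that less compound is tolerated, a higher number that more compound is tolerated:

Compound 1, `O=C1C=CC(O)(c2cc3ccc(F)cc3n2S(=O)(=O)c2ccccc2)C=C1`: 2240 nM
Compound 2, `CC(C)c1cc(C(C)C)c(S(=O)(=O)n2c(C3(O)C=CC(=O)C=C3)cc3ccccc32)c(C(C)C)c1`: 11200 nM
Compound 3, `O=C1C=CC(O)(c2cc3ccccc3n2S(=O)(=O)c2ccc3ccccc3c2)C=C1`: 5620 nM

Among these three numbers compound 3 stands second highest. Its nearest neighbour is compound 2, whose value lies within the usual scatter of compound 3, so the two cannot be told apart. Compound 1, by contrast, sits at a lower number than compound 3, and this gap is beyond the scatter; compound 1 carries a phenyl on the sulfonyl sulfur and a fluorine on the shared core, so it differs from compound 3 in two places at once and no single-step comparison is available.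

The next compound to be measured is compound 4, `O=C1C=CC(O)(c2cc3ccccc3n2S(=O)(=O)c2ccccc2)C=C1`. It differs from compound 3 in one place only:

phenyl in place of naphthalen-2-yl on a sulfonyl sulfur

Within the data shown here, no step between measured compounds is known for this change. Because compound 1, which also carries a phenyl on the sulfonyl sulfur, gives 2240 nM, a shift toward a lower number in this assay is expected for compound 4, though a modest one that may not clear the scatter. Compound 4 is estimated at 3500 nM, with a range from 1500 nM to 8000 nM, which amounts to an expected step of a 1.6-fold lower number from compound 3 to compound 4 (0.21 log units; within the scatter).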

Compound 4, concentration lethal to 50% of the cells: 2950 nM
Beside the measured number, compound 4's estimate is 1.2-fold (0.07 log units) above it; measured number inside the range.
By their numbers in this assay, from the lowest: compounds 1, 4, 3 and 2 (each within the scatter of the next, the first and the last beyond it).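

In this assay, phenyl in place of naphthalen-2-yl on a sulfonyl sulfur gives a 1.9-fold lower number from compound 3 to compound 4 (0.28 log units; within the scatter). Among these compounds, this is the first single-place reading at this sulfonyl sulfur, and it shows that the group with one six-membered aromatic ring and the group with two cannot be told apart in this assay. Among the compounds shown here, the first single-place reading on the shared core, hydrogen in place of fluoro on an aromatic carbon, gives a 1.3-fold higher number from compound 1 to compound 4 (0.12 log units; within the scatter), so these two compounds cannot be told apart either, and no evidence is available to explain either result.

The compounds shown leave open whether any group on this sulfonyl sulfur other than an aromatic ring of carbon only, such as a short alkyl chain or a pyridine ring, would move the number beyond the scatter. They also leave open whether an amine or a carboxylic acid carried on the phenyl, or a chlorine or a methoxy group in place of the fluoro on the shared core, would give a step that can be read in this assay.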